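Cytotoxicity on liver cells: a ring opened into a chain

The compounds below may be only part of what the source reports. "The series", "measured", "known", "first", "only" and "open" are said of these compounds alone.

Compound 1 `NS(=O)(=O)c1ccc(NC2=NC(=O)CS2)cc1`: 43000 nM
Compound 2 `N#CC1=C(N)Oc2nc(Nc3ccc(S(N)(=O)=O)cc3)sc2C1c1cccc(Br)c1`: 72000 nM
Compound 3 `N#CC1=C(N2C(=O)CCC2=O)Oc2nc(Nc3ccc(S(N)(=O)=O)cc3)sc2C1c1ccc([N+](=O)[O-])cc1`: 45000 nM

In a functional assay on HepG2 cells (Homo sapiens) for cytotoxicity, read by sulforhodamine B assay, with a stated time of 48 h (on this read-out lower numbers stand for stronger inhibition and higher numbers for weaker inhibition), compound 3 gives 45000 nM. Its number lies within the scatter of that of compound 1 and of that of compound 2, so the three measured compounds cannot be told apart on this read-out. Compound 4 `CC(=O)CC(=O)NC1=C(C#N)C(c2ccc([N+](=O)[O-])cc2)c2sc(Nc3ccc(S(N)(=O)=O)cc3)nc2O1` differs from compound 3 in one place: ((2-oxopropyl)carbonyl)amino in place of 2,5-dioxopyrrolidin-1-yl on a double-bonded ring carbon. Among the measured compounds shown here, no pair of measured compounds shows such a change, so no measured step guides the expectation. Compound 4 is expected to stay with the three measured numbers, with no change at the digits printed from compound 3 to compound 4 (within the scatter) amounting to nothing beyond the scatter. The estimate for compound 4 is 45000 nM, with a range from 15000 nM to 140000 nM.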

Compound 4, half-maximal inhibitory concentration: 37000 nM
For compound 4 the middle estimate is 1.2-fold (0.09 log units) above the measured one, and the stated range covers the measured number.
By their numbers in this assay, from the lowest: compounds 4, 1, 3 and 2 (each within the scatter of the next).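

In this assay, the 2,5-dioxopyrrolidin-1-yl ring gives way to the open ((2-oxopropyl)carbonyl)amino chain on the double-bonded ring carbon with a 1.2-fold lower number from compound 3 to compound 4 (0.09 log units; within the scatter), a step within the scatter. Among the compounds shown here, this gives the series its only single-place comparison, and at this position the loss of the ring and the added hydrogen-bond donor leave compound 3 and compound 4 indistinguishable. Nothing available explains this result. The compounds shown leave open whether a free amine, a carboxylic acid or a longer chain on this carbon would move the number beyond the scatter.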